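The compounds below may be only part of what the source reports. "The series", "measured", "known", "first", "only" and "open" are said of these compounds alone.

Compound 1, with structure `COC(=O)c1cc(=O)c2c(OC)cc(OC)cc2n1C`, and compound 2, with structure `COc1cc(OC)c2c(=O)cc(C(=O)Nc3ccc(N4CCN(C)CC4)cc3)[nH]c2c1`, were both tested in a functional assay on SEM cells (Homo sapiens) for antiproliferative activity, with a stated time of 72 h; a higher number here means that more compound is needed for the effect, a lower number that less compound is needed. For compound 1 the result is a limit of the assay rather than a number, > 19000 nM. For compound 2 the result is likewise a limit, > 19800 nM. Compound 2 therefore stands at the edge of what the assay could report; both values shown sit at such limits, as summarized by the limit of > 19000 nM in this assay, at which 1 of the 2 values shown sits, and (the limit of > 19800 nM in this assay, at which 1 of the 2 values shown sits), so no ordering of the two compounds can be drawn. Compound 3, with structure `COc1cc(OC)c2c(=O)cc(C(=O)Nc3ccc(Oc4cccnc4)cc3)[nH]c2c1`, has not yet been tested in this assay. It differs from compound 2 by (pyridin-3-yl)oxy in place of 4-methylpiperazin-1-yl on an aromatic carbon. For the measured compounds named here, no measured pair shows what such a change does here, so the direction of the step is uncertain, and a result at or near the limit is taken as the more likely outcome. The estimated step is an at least 1.3-fold lower number from compound 2 to compound 3 (0.12 log units; that floor lies within the scatter). Compound 3 is expected to give 15000 nM, with a range from 3000 nM to 25000 nM.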

Compound 3, half-maximal effective concentration: > 32100 nM
Compound 3: only a limit was reported; the forecaster's own chance of this, stated with the estimate: 60%; middle value at least 2.1-fold (0.33 log units) away from the limit.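

In this assay compound 3 gives > 32100 nM as a limit of the assay, not a number. Compound 2 also gives a limit, > 19800 nM and so the step between these two compounds cannot be read. The compounds shown leave open whether (pyridin-3-yl)oxy in place of 4-methylpiperazin-1-yl changes antiproliferative activity at all.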